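Swapping 5-methylfuran-2-yl for 3-chlorophenyl in compound 3

The source may hold more compounds than are shown below. What is called first, only, known or untested is meant among the compounds shown, and "the series" means these compounds.

- compound 1 `Clc1ccc(-c2cc(-c3ccsc3)nc(-c3ccccc3Cl)c2)o1`: 4570 nM
- compound 2 `Cc1cccc(-c2cc(-c3ccc(Cl)o3)cc(-c3ccsc3)n2)c1`: 21700 nM
- compound 3 `Cc1ccc(-c2cc(-c3ccc(Cl)o3)cc(-c3ccsc3)n2)o1`: > 50000 nM

The values above come from a functional assay on HCT-15 cells (Homo sapiens) for cytotoxicity, in the presence of a further agent that is not named here; a lower number here means a stronger inhibitor, a higher number a weaker inhibitor. Compound 3 is the weakest of the three, and its reading of > 50000 nM is a limit of the assay, not a number.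

Compound 4 `Clc1cccc(-c2cc(-c3ccc(Cl)o3)cc(-c3ccsc3)n2)c1` keeps the shared core and carries 3-chlorophenyl in place of 5-methylfuran-2-yl, on an aromatic carbon next to the ring nitrogen: 3-chlorophenyl in place of 5-methylfuran-2-yl on an aromatic carbon.

All three measured steps bear on this change. Placing 5-methylfuran-2-yl at this carbon gave an at least 10-fold higher number from compound 1 to compound 3 (1.03 log units; beyond the scatter), starting from 2-chlorophenyl, and an at least 2.3-fold higher number from compound 2 to compound 3 (0.36 log units; beyond the scatter), starting from 3-methylphenyl. Between the two phenyl-bearing compounds, 3-methylphenyl in place of 2-chlorophenyl gave a 4.7-fold higher number from compound 1 to compound 2 (0.68 log units; beyond the scatter).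

The 3-chlorophenyl group most resembles the aryl groups of compound 1 and compound 2, so compound 4 is expected to fall between those two or close to them. A step to a lower number in this assay, at least modest and beyond the scatter, is therefore expected. The expected change is an at least 4.5-fold lower number from compound 3 to compound 4 (0.65 log units; beyond the scatter). For compound 4 the estimate is 11000 nM, with an expected range of 3500 nM to 35000 nM.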

Compound 4, half-maximal inhibitory concentration: 13700 nM
For compound 4 the middle estimate is 1.2-fold (0.10 log units) below the measured one, within the range that was stated.
By their numbers in this assay, from the lowest: compound 1; then compounds 4 and 2 (each within the scatter of the next). At a limit, above all of these: compound 3.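

In this assay, 3-chlorophenyl in place of 5-methylfuran-2-yl gives an at least 3.6-fold lower number from compound 3 to compound 4 (0.56 log units; beyond the scatter), so this position gives a measurable reading with 3-chlorophenyl as well as with 3-methylphenyl, while 5-methylfuran-2-yl does not. The reading of compound 3 is a limit and not a number: the limit of > 50000 nM in this assay, at which 1 of the 4 values shown sits.

Chloro in place of methyl on the phenyl ring gives a 1.6-fold lower number from compound 2 to compound 4 (0.20 log units; within the scatter), so the two 3-substituted phenyl groups cannot be told apart here, whereas 3-chlorophenyl in place of 2-chlorophenyl gives a 3.0-fold higher number from compound 1 to compound 4 (0.48 log units; beyond the scatter), which shows that, with the chlorine kept, its place on the phenyl ring alters the reading.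

The compounds shown leave open whether the lower number of compound 1 belongs to a chloro group in particular or would also appear with 2-methylphenyl, and how unsubstituted phenyl or 4-chlorophenyl would compare. They also leave open how a phenyl ring carrying an amine or a carboxylic acid would read at this carbon, and how much of the reading depends on the further agent present in this assay.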